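Amide Enlargement on a Shared Triazine Core

This account rests on a few compounds, and the source may have more. Where it says the series, first, only, none or still open, it means among the compounds named here.

Compound 2 `CC(=O)N1CCN(c2nnc3nncn3n2)CC1` gives the highest of the three numbers measured in a functional assay on BeWo cells (Homo sapiens) for inhibition, read by MTT assay, with a stated time of 72 h (a higher number here means a weaker inhibitor, a lower number a stronger inhibitor), at 13100 nM. Compound 3 `CN1CCN(c2nnc3nncn3n2)CC1` lies nearest, with 7990 nM, and compound 1 `c1nnc2nnc(N3CCCC3)nn12` lies furthest, with 4290 nM. Compound 4 `O=C(C1CCCCC1)N1CCN(c2nnc3nncn3n2)CC1` differs from compound 2 by cyclohexyl in place of methyl on a carbonyl carbon. For the measured compounds named here, the one measured step, a 1.6-fold lower number from compound 2 to compound 3 (0.21 log units; within the scatter), replaces the acetyl entirely and stays within the scatter, while no measured pair tests a larger group on the carbonyl carbon. Since removing the acetyl changed little, a step of a 1.3-fold lower number from compound 2 to compound 4 (0.12 log units; within the scatter) is expected here, not beyond the scatter in either direction. Compound 4 is therefore estimated at 10000 nM, with a range from 3000 nM to 33000 nM.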

Compound 4, half-maximal inhibitory concentration: 1900 nM
Beside the measured number, compound 4's estimate is 5.3-fold (0.72 log units) above it, outside the stated range (below it).
By their numbers in this assay, from the lowest: compound 4; then compounds 1, 3 and 2 (each within the scatter of the next, the first and the last beyond it).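

In this assay the group on the carbonyl carbon matters: cyclohexyl in place of methyl gives a 6.9-fold lower number from compound 2 to compound 4 (0.84 log units; beyond the scatter) and so lies beyond the scatter, unlike the earlier 1.6-fold lower number from compound 2 to compound 3 (0.21 log units; within the scatter) and its replacement of the whole acetyl. The amide carbonyl therefore does not rule out a stronger inhibitor in this series, and a larger carbon-only ring on it is tolerated here. No evidence is available that bears on this step. As far as these compounds go, whether a phenyl ring or an open butyl chain on the same carbonyl carbon would match cyclohexyl remains open.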